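This account rests on a few compounds, and the source may have more. Where it says the series, first, only, none or still open, it means among the compounds named here.

For the measured compounds named here, in a functional assay on PC-3 cells (Homo sapiens) for antiproliferative activity, read by MTT assay, with a stated time of 72 h (on this read-out higher numbers stand for weaker inhibition and lower numbers for stronger inhibition), compound 1 `CCCCCCCCCCNC[C@@H]1OC[C@H](N)[C@@H]1O` gives 11900 nM, the only exact number so far. Its partner, compound 2 `CCCCCCCCCCNC[C@@H]1OC[C@H](N)[C@H]1O`, reads > 128000 nM, which is a limit of the assay and not a number. Going by the values given here, the one measured step, an at least 10-fold higher number from compound 1 to compound 2 (1.03 log units; beyond the scatter), is large, but it comes with the fact that compounds 1 and 2 differ only in the configuration as drawn, so it says nothing direct about a change in the chain. Compound 3 `CCCCCCCCCNC[C@@H]1OC[C@H](N)[C@@H]1O` keeps the core of compound 1 and alters only the chain end: hydrogen in place of methyl on a saturated chain carbon, nine bonds along the chain from an amine nitrogen. Among the compounds with values here, no measured step touches the chain, so the size of this change remains an open question, and a small shift towards a higher number, perhaps within the scatter, is the cautious expectation. The estimated step is a 1.3-fold higher number from compound 1 to compound 3 (0.13 log units; within the scatter). For compound 3 the expected value is 16000 nM, with an estimated range of 7000 nM to 36000 nM.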

Compound 3, half-maximal inhibitory concentration: 2030 nM
Compound 3: middle estimate off by 7.9-fold (0.90 log units), on the high side; measured number outside the range, below it.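

In this assay, for the compounds shown here, the first measured step at the chain shows that its end is not a neutral place to change: a 5.9-fold lower number from compound 1 to compound 3 (0.77 log units; beyond the scatter). The change is hydrogen in place of methyl on a saturated chain carbon, nine bonds along the chain from an amine nitrogen, and with the core of compound 1 kept intact it gives stronger inhibition of these cells, by more than the usual scatter. Nothing measured on these compounds points to a reason for this step.

Going by these compounds, a single step makes no trend, so it remains open whether a still shorter chain would continue in this direction, or whether a hydroxyl or a carboxylic acid at the chain end would be tolerated. On these data alone, it is also open whether the configuration at the ring carbon matters as much with the shorter chain of compound 3 as it does with the chain of compound 1.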